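The source may report more compounds than this note shows. Statements on the series, on what has been measured and on what is new or still open speak of the compounds shown alone.

Working notes on the series, ileum binding.

Of the compounds shown here, three carry a number so far. Compound 1 `CNC(=O)C(CCn1ccnc1C)(c1ccccc1)c1ccccc1` gives 5150 nM in an assay on ileum with muscarinic acetylcholine receptor M3 (Cavia porcellus) as the target; a lower number here means a stronger inhibitor, a higher number a weaker inhibitor. Compound 2 `Cc1nccn1CCC(C(N)=O)(c1ccc(F)cc1)c1ccc(F)cc1` gives 9.85 nM in this assay, the lowest of the three. Compound 3 `Cc1nccn1CCC(C)(C(N)=O)c1ccccc1` gives 1830 nM in this assay, the second highest of the three numbers: compound 1 sits nearest to it, with a higher number that still lies beyond the scatter, while compound 2 is furthest away, with a far lower number.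

Compound 4 `Cc1nccn1CCC(C(N)=O)(c1ccccc1)C1CCCCC1` is the next compound and has no number yet. It differs from compound 3 in one place: cyclohexyl in place of methyl on a saturated chain carbon bound to an aromatic carbon, a carbonyl carbon and a saturated chain carbon. Within the data shown here, no two measured compounds differ in this single place, so the step has no measured precedent. What the numbers show is that the two compounds with two ring groups on the branching carbon, compound 1 and compound 2, frame compound 3, and that compound 2, whose two aryl groups make the fullest pair of rings here, gives by far the lowest number, 9.85 nM.

Against that background the step in this assay is expected to be large and downward, a 46-fold lower number from compound 3 to compound 4 (1.66 log units; beyond the scatter). Compound 4 is therefore expected to give about 40 nM, with a range from 6 nM to 250 nM, since compound 3 at 1830 nM is the starting point and the second ring is judged to move the number toward that of compound 2.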

Compound 4, antagonist equilibrium constant: 19 nM
The estimate for compound 4 lay 2.1-fold (0.32 log units) above the measured number, and the stated range covers the measured number.
By their numbers in this assay, from the lowest: compounds 2 and 4 (each within the scatter of the next); then compound 3; then compound 1.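

In this assay, cyclohexyl in place of methyl on a saturated chain carbon bound to an aromatic carbon, a carbonyl carbon and a saturated chain carbon gives a 96-fold lower number from compound 3 to compound 4 (1.98 log units; beyond the scatter). Among these compounds, this is the first measured single-place step, and it shows that the number at this position responds strongly to the group carried there, with a non-aromatic ring of carbon only sufficing for a large drop. No measurement at hand accounts for the size of this step.

On these data alone, whether the drop requires a ring at all, or whether a longer chain such as n-butyl would do the same, stays open. So does the outcome for a smaller ring such as cyclopropyl, or for a cyclohexyl ring carrying an amine.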